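This account rests on a few compounds, and the source may have more. Where it says the series, first, only, none or still open, it means among the compounds named here.

The series here rests on one shared core, varied only at the sulfonamide nitrogen. Compound 1 `CNS(=O)(=O)c1ccc2c(c1)C(n1ccccc1=O)=CC(C)(C)O2` is the simplest member, and in a functional assay on the whole organism (trachea) with Rattus norvegicus as the target (a higher number here means a larger maximal response, a lower number a smaller maximal response), compound 1 gives 83%. Compound 2 `CC(C)NS(=O)(=O)c1ccc2c(c1)C(n1ccccc1=O)=CC(C)(C)O2` carries a larger group on that nitrogen, and in this assay compound 2 gives 94.8%. The single step recorded so far, a number 11.8 percentage points higher from compound 1 to compound 2 (beyond the scatter), therefore leaves compound 1 with the lower of the two numbers shown.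

Compound 3 `CN(c1ccccc1)S(=O)(=O)c1ccc2c(c1)C(n1ccccc1=O)=CC(C)(C)O2` has not yet been measured in this assay. It differs from compound 1 by phenyl in place of hydrogen on a sulfonamide nitrogen. Going by the values given here, the one measured step that bears on this change is a number 11.8 percentage points higher from compound 1 to compound 2 (beyond the scatter), since it also alters what the sulfonamide nitrogen carries; but that step kept the nitrogen's hydrogen and exchanged only the alkyl group, whereas compound 3 loses the hydrogen and gains an aromatic ring while the methyl stays. Among the compounds with values here, with only that one comparison to lean on, a step of no more than modest size is expected for a number 4 percentage points higher from compound 1 to compound 3 (within the scatter), with considerable uncertainty about its direction. Compound 3 is therefore estimated at 87%, within 65% to 103%.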

Compound 3, largest response reached (Emax), in percent of the reference or control that the assay uses: 86.5%
Compound 3: the middle estimate sits 0.5 percentage points above what was measured, and the stated range covers the measured number.
By their numbers in this assay, from the lowest: compounds 1, 3 and 2 (each within the scatter of the next, the first and the last beyond it).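

The earlier pair varied only the alkyl group and kept the hydrogen on the sulfonamide nitrogen, whereas compound 3 shows what happens when that hydrogen gives way to phenyl and the methyl stays: in this assay, the step is within the scatter (a number 3.5 percentage points higher from compound 1 to compound 3 (within the scatter)). Compound 3 also lies within the scatter of the isopropyl compound (a number 8.3 percentage points lower from compound 2 to compound 3 (within the scatter)), so it cannot be separated from either neighbour, even though those two are separated from each other (a number 11.8 percentage points higher from compound 1 to compound 2 (beyond the scatter)). The position therefore accepts a nitrogen that carries phenyl and no hydrogen, and the maximal response stays within the span set by the two compounds that keep the hydrogen. The data offer no measured property that would account for these numbers.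

With only compound 3 lacking that hydrogen, its loss cannot be told apart from the arrival of the phenyl ring, and a dimethylamino group on the sulfonyl sulfur would separate the two. On these data alone, how a benzyl group, a longer chain or a carboxylic acid on this nitrogen would fare also stays open.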